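This account rests on a few compounds, and the source may have more. Where it says the series, first, only, none or still open, it means among the compounds named here.

Of the compounds shown here, three sharing one core have been measured in a functional assay on HeLa cells (Homo sapiens) for inhibition, read by MTT assay, with a stated time of 48 h; a higher number here means a weaker inhibitor, a lower number a stronger inhibitor. Compound 2 `CCOC(=O)C1=C(N)Nc2[nH]nc(C)c2C1c1ccc(N(C)C)cc1` gives 6220 nM, compound 1 `CCOC(=O)C1=C(NN=C(C#N)C#N)Nc2[nH]nc(C)c2C1c1ccc(N(C)C)cc1` gives 15200 nM, and compound 3 `CCOC(=O)C(=NNC1=C(C(=O)OCC)C(c2ccc(N(C)C)cc2)c2c(C)n[nH]c2N1)C(=O)OCC` gives 83800 nM, the highest of the three numbers: its nearest neighbour is compound 1, with a 5.5-fold higher number from compound 1 to compound 3 (0.74 log units; beyond the scatter), and its furthest is compound 2, with a 13-fold higher number from compound 2 to compound 3 (1.13 log units; beyond the scatter). Compound 4 `CCOC(=O)C1=C(N/N=C(/Cl)c2ccc([N+](=O)[O-])cc2)Nc2[nH]nc(C)c2C1c1ccc(N(C)C)cc1` differs from compound 3 by a group of 12 heavy atoms (7 carbon, 2 nitrogen, 2 oxygen, 1 chlorine; one six-membered aromatic ring of carbon only) in place of a group of 12 heavy atoms (7 carbon, 1 nitrogen, 4 oxygen; no ring), on an amine nitrogen. Within the data shown here, no measured step exchanges one group of that size for another on the amine nitrogen; the steps that bear on it are those that changed what sits there, a 2.4-fold lower number from compound 1 to compound 2 (0.39 log units; beyond the scatter), a 5.5-fold higher number from compound 1 to compound 3 (0.74 log units; beyond the scatter) and a 13-fold higher number from compound 2 to compound 3 (1.13 log units; beyond the scatter), all modest or large. Since compound 4 keeps a group of the same count as compound 3 but of a different kind, a step of modest size in either direction is expected in this assay, with a slight lean downward toward the number of compound 1. Compound 4 is therefore estimated at 35000 nM, with a range of 9000 nM to 130000 nM, which is expected to mean a 2.4-fold lower number from compound 3 to compound 4 (0.38 log units; beyond the scatter).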

Compound 4, half-maximal inhibitory concentration: 46200 nM
Compound 4: middle estimate off by 1.3-fold (0.12 log units), on the low side; measured number inside the range.
By their numbers in this assay, from the lowest: compound 2; then compound 1; then compounds 4 and 3 (each within the scatter of the next).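

In this assay, the amine nitrogen carries two different groups of 12 heavy atoms with no separation beyond the scatter (a 1.8-fold lower number from compound 3 to compound 4 (0.26 log units; within the scatter)), so a six-membered aromatic ring of carbon only and a chlorine in the entering group do not set compound 4 apart from compound 3. Smaller groups on this nitrogen do stand apart from the new group, with a hydrogen atom in one step (a 7.4-fold higher number from compound 2 to compound 4 (0.87 log units; beyond the scatter)) and the group of 6 heavy atoms in the other (a 3.0-fold higher number from compound 1 to compound 4 (0.48 log units; beyond the scatter)), and across these four compounds none goes against the rise in the number with the size of the group. No evidence is at hand that would explain this.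

The compounds shown leave open whether a methyl or an acetyl group on this nitrogen would stay close to compound 2. Also open, as far as these compounds go, is what a plain phenyl group or a carboxylic acid would do in place of the group entering in compound 4.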